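Halogen swap on the aryl group of compound 3

The source may hold more compounds than are shown below. What is called first, only, known or untested is meant among the compounds shown, and "the series" means these compounds.

Compound 3 `Oc1cc(C(F)(F)F)ccc1-c1nc(-c2ccccc2O)n(-c2ccc(F)cc2)n1` gives 99.8% in a functional assay on PC-12 cells (Rattus norvegicus) for cytotoxicity, read by MTT assay, with stated times of 2 h and 24 h, tested at 10 uM (on this read-out higher numbers stand for a stronger effect at the one concentration tested and lower numbers for a weaker effect), the second highest of the three numbers. Compound 1 `CC(C)c1ccc(-n2nc(-c3ccc(C(F)(F)F)cc3O)nc2-c2ccccc2O)cc1` gives 108%, within the scatter of compound 3, while compound 2 `CC(C)(C)c1ccc(-n2nc(-c3ccc(C(F)(F)F)cc3O)nc2-c2ccccc2O)cc1` gives 81.1%; the step of a number 18.7 percentage points higher from compound 2 to compound 3 (beyond the scatter) is beyond the scatter. Compound 4 `Oc1cc(C(F)(F)F)ccc1-c1nc(-c2ccccc2O)n(-c2ccc(Cl)cc2)n1` differs from compound 3 by chloro in place of fluoro on an aromatic carbon. Going by the values given here, no measured step swaps one halogen for another. The steps that do bear on the group at that aromatic carbon are a number 8.2 percentage points lower from compound 1 to compound 3 (within the scatter), within the scatter, and a number 18.7 percentage points higher from compound 2 to compound 3 (beyond the scatter), modest. Neither suggests a large shift for a single-atom exchange. The step of a number 1.8 percentage points lower from compound 3 to compound 4 (within the scatter) is therefore expected to stay within the scatter. Compound 4 is estimated at 98%, between 80% and 115%.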

Compound 4, a percentage reported as activity, at one concentration (the size of the read-out at that concentration, not a potency): 96.1%
Beside the measured number, compound 4's estimate is 1.9 percentage points above it; the measured number falls inside the stated range.
By their numbers in this assay, from the lowest: compound 2; then compounds 4, 3 and 1 (each within the scatter of the next, the first and the last beyond it).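

In this assay, going by these compounds alone, the step of a number 3.7 percentage points lower from compound 3 to compound 4 (within the scatter) is the first direct exchange of one halogen for another at this carbon, and 4-fluorophenyl to 4-chlorophenyl leaves the read-out within the scatter. The steps of a number 15 percentage points higher from compound 2 to compound 4 (beyond the scatter) and a number 11.9 percentage points lower from compound 1 to compound 4 (beyond the scatter) separate chloro from both tert-butyl and isopropyl, whereas fluoro stayed within the scatter of isopropyl. Nothing measured here explains any of these steps.

Open, going by these compounds, is whether bromo, a methoxy group, an amine or a carboxylic acid at this carbon would stay within the scatter of compound 3.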